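Adding a methyl to the amine of compound 2

The source may hold more compounds than are shown below. What is called first, only, known or untested is meant among the compounds shown, and "the series" means these compounds.

Compound 1 `COc1ccc(C(=O)c2ccc3c(c2)C=CC(C)(C)O3)c(NC(=O)CO)c1` and compound 2 `CNCC(=O)Nc1cc(OC)ccc1C(=O)c1ccc2c(c1)C=CC(C)(C)O2` share one core and differ only in the group on a saturated chain carbon bound to a carbonyl carbon. In a functional assay on A549 cells (Homo sapiens) for antiproliferative activity, read by MTT assay, with a stated time of 48 h (a higher number here means a weaker inhibitor, a lower number a stronger inhibitor), compound 1 gives 90 nM, and compound 2 gives 800 nM. Compound 2 therefore holds the higher of the two numbers and is the weaker inhibitor of the pair. The gap is an 8.9-fold higher number from compound 1 to compound 2 (0.95 log units; beyond the scatter), with methylamino in place of hydroxy.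

Compound 3 `COc1ccc(C(=O)c2ccc3c(c2)C=CC(C)(C)O3)c(NC(=O)CN(C)C)c1` follows from compound 2 through methyl in place of hydrogen on an amine nitrogen, so methylamino becomes dimethylamino.

For the measured compounds named here, only one measured step bears on this change. The step of an 8.9-fold higher number from compound 1 to compound 2 (0.95 log units; beyond the scatter) shows that a swap at this chain carbon can move the number beyond the scatter, but it replaces hydroxy and does not alter an existing amine. Going by the values given here, no measured pair shows what methylating this nitrogen does, so the direction remains open. The expected change in this assay is small, a 1.1-fold lower number from compound 2 to compound 3 (0.06 log units; within the scatter), and not expected to exceed the scatter. For compound 3 the estimated value is 700 nM, with an expected range of 220 nM to 2200 nM.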

Compound 3, half-maximal inhibitory concentration: 1160 nM
Compound 3: middle estimate off by 1.7-fold (0.22 log units), on the low side; measured number inside the range.
By their numbers in this assay, from the lowest: compound 1; then compounds 2 and 3 (each within the scatter of the next).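

In this assay the methylation of this amine nitrogen gives a 1.5-fold higher number from compound 2 to compound 3 (0.16 log units; within the scatter) and so does not separate the two amines: methylamino and dimethylamino read alike at this chain carbon, and the added methyl leaves no change that can be told from the scatter. The comparison with hydroxy now rests on two amines, as dimethylamino in place of hydroxy gives a 13-fold higher number from compound 1 to compound 3 (1.11 log units; beyond the scatter) and compound 1, the strongest inhibitor of the three, stands apart from both compound 2 and compound 3 by steps beyond the scatter, so the loss seen with methylamino is not confined to that one amine. No measurement in hand accounts for the gap between hydroxy and the two amines or for the lack of a clear step between the amines.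

Hydroxy remains the only group at this chain carbon without a nitrogen, so one compound carries the whole low end of the series, and a methoxy, a primary amine or a carboxylic acid could fall on either side of the gap. On these data alone, how a bulkier amine such as morpholine or a longer chain between the carbonyl and the amine would read in this assay also stays open.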